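The source may hold more compounds than are shown below. What is called first, only, known or untested is meant among the compounds shown, and "the series" means these compounds.

Values so far in a physicochemical assay for solubility, read by chemiluminescence, measured as kinetic solubility; on this read-out higher numbers stand for higher solubility and lower numbers for lower solubility
- compound 1 `COc1cccc2c1c(NS(=O)(=O)c1ccc(Cl)s1)nn2Cc1cccc(CNC(=O)C2CCO2)c1` gives 124 ug/mL
- compound 2 `COc1cccc2c1c(NS(=O)(=O)c1ccc(Cl)s1)nn2Cc1cccc(CNC(=O)C2CCOCC2)c1` gives >= 193 ug/mL (a limit of the assay, not a number)
- compound 3 `CN[C@H](C)C(=O)NCc1cccc(Cn2nc(NS(=O)(=O)c3ccc(Cl)s3)c3c(OC)cccc32)c1` gives 191 ug/mL

Compound 3 has its nearest number in compound 1. That pair reads a 1.5-fold higher number from compound 1 to compound 3 (0.19 log units; within the scatter) and the two cannot be told apart. For compound 2 the entry is the limit of >= 193 ug/mL in this assay, at which 1 of the 3 values shown sits, and no number exists.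

Compound 4 `COc1cccc2c1c(NS(=O)(=O)c1ccc(Cl)s1)nn2Cc1cccc(CNC2COC2)c1` carries oxetan-3-yl in place of (1-(methylamino)ethyl)carbonyl on an amine nitrogen, the count being oxetan-3-yl in place of (1-(methylamino)ethyl)carbonyl on an amine nitrogen and the carbonyl on that nitrogen goes with it.

The measured steps that bear on this only swap the group on a carbonyl carbon. One reads an at least 1.5-fold higher number from compound 1 to compound 2 (0.19 log units; that floor lies within the scatter) and stays inside the scatter. Another reads a number no higher from compound 2 to compound 3 (the limit leaves the size open) with its size left open. None of them removes the carbonyl, so the support is indirect.

With compound 3 at 191 ug/mL and the step of a 1.5-fold higher number from compound 1 to compound 3 (0.19 log units; within the scatter) inside the scatter, no step beyond the scatter is expected in this assay for this change, with only a slight downward lean. The estimated step is a 1.3-fold lower number from compound 3 to compound 4 (0.10 log units; within the scatter) and it stays inside the scatter. For compound 4 the expected value is 150 ug/mL with an estimated range of 75 ug/mL to 200 ug/mL on this read-out.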

Compound 4, solubility: 122 ug/mL
The estimate for compound 4 lay 1.2-fold (0.09 log units) above the measured number; the range from low to high includes it.
By their numbers in this assay, from the lowest: compounds 4, 1 and 3 (each within the scatter of the next). At a limit, above all of these: compound 2.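

Among the compounds shown, only one lacks the carbonyl on this amine nitrogen, so the removal of that carbonyl can now be read directly: in this assay, oxetan-3-yl in place of (1-(methylamino)ethyl)carbonyl gives a 1.6-fold lower number from compound 3 to compound 4 (0.19 log units; within the scatter). Oxetan-3-yl in place of (oxetan-2-yl)carbonyl, which keeps a four-membered ring with one oxygen on both sides of the change, gives a 1.0-fold lower number from compound 1 to compound 4 (0.01 log units; within the scatter), so neither pair with a number on both sides moves beyond the scatter when the carbonyl goes. Oxetan-3-yl in place of (oxan-4-yl)carbonyl gives an at least 1.5-fold lower number from compound 2 to compound 4 (0.19 log units; that floor lies within the scatter), and the entry for compound 2 is a limit of the assay and not a number, which leaves the true size of this step unread: the limit of >= 193 ug/mL in this assay, at which 1 of the 4 values shown sits.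

It remains open whether any group on this nitrogen moves the read-out beyond the scatter, as all the numbers shown lie within it of one another. A carboxylic acid on a short chain, a piperidin-4-yl ring or the bare primary amine on the same saturated chain carbon would test that, and the four compounds shown say nothing about any of them.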